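The source may report more compounds than this note shows. Statements on the series, on what has been measured and on what is new or still open speak of the compounds shown alone.

Measured so far in a functional assay on brain (Rattus norvegicus, strain Wistar) for inhibition; a lower number here means a stronger inhibitor, a higher number a weaker inhibitor

- compound 1 `Cc1[nH]c(=O)n(C)c1-c1ccc(OCCC(C)C)cc1` gives 6600 nM
- compound 2 `Cc1[nH]c(=O)n(C2CCCCC2)c1-c1ccc(OC(C)C)cc1` gives 13000 nM
- compound 3 `Cc1[nH]c(=O)n(C2CCCCC2)c1-c1ccc(CC(C)C)cc1` gives 10900 nM

Compound 3 at 10900 nM lies within the scatter of compound 2 at 13000 nM and also within the scatter of compound 1 at 6600 nM so its number does not separate it from either.

The next change gives compound 4 `Cc1[nH]c(=O)n(C2CCCCC2)c1-c1ccc(OCCC(C)C)cc1` with isopentyloxy in place of isobutyl on an aromatic carbon, para to a large group. Counted, the difference is isopentyloxy in place of isobutyl on an aromatic carbon and nothing else in the structure changes.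

Among the measured compounds shown here, one measured step bears directly on this place. It is a 1.2-fold lower number from compound 2 to compound 3 (0.08 log units; within the scatter) for isobutyl in place of isopropoxy, and it stays within the scatter. Compound 1 also carries isopentyloxy but differs from compound 4 elsewhere, so compound 1 at 6600 nM is only a loose guide. For the measured compounds named here, no measured step isolates isopentyloxy in the background of compound 3.

No step beyond the scatter is therefore expected in this assay and any shift should lean toward the number of compound 1. The expected step is a 1.4-fold lower number from compound 3 to compound 4 (0.13 log units; within the scatter) as an estimate only. For compound 4 the estimated value is 8000 nM with an expected range from 3000 nM to 20000 nM in this assay.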

Compound 4, half-maximal inhibitory concentration: 7200 nM
The estimate for compound 4 lay 1.1-fold (0.05 log units) above the measured number; measured number inside the range.
By their numbers in this assay, from the lowest: compounds 1, 4, 3 and 2 (each within the scatter of the next).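

In this assay, isopentyloxy in place of isobutyl on the aromatic carbon gives a 1.5-fold lower number from compound 3 to compound 4 (0.18 log units; within the scatter) and isopentyl in place of isopropyl on the oxygen gives a 1.8-fold lower number from compound 2 to compound 4 (0.26 log units; within the scatter) so, with cyclohexyl held on the aromatic nitrogen, isopropoxy, isobutyl and isopentyloxy are not separated at this position. The series now also has its first one-place reading at the nitrogen: with isopentyloxy held fixed, cyclohexyl in place of methyl gives a 1.1-fold higher number from compound 1 to compound 4 (0.04 log units; within the scatter) and the assay does not separate these two groups either. No evidence on the cause of these steps is available.

Going by these compounds, it remains open whether any group on this aromatic carbon can move the number beyond the scatter, and a carboxylic acid, an amine or a chain longer than isopentyloxy would test this. Also open, on these data alone, is whether a benzyl group or a plain hydrogen on the aromatic nitrogen would stand apart from cyclohexyl and methyl.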